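Pent-1-en-1-yl in place of vinyl on compound 2

This account rests on a few compounds, and the source may have more. Where it says the series, first, only, none or still open, it means among the compounds named here.

Of the compounds shown here, two have measured values so far. In a functional assay on A549 cells (Homo sapiens) for antiproliferative activity, read by MTT assay, with a stated time of 72 h (a higher number here means a weaker inhibitor, a lower number a stronger inhibitor), compound 1 (`CCC/C=C/C(=O)Nc1cccc(Oc2nc(Nc3ccn(C)n3)nc3c2CSCC3)c1`) gives 8190 nM and compound 2 (`C=CC(=O)Nc1cccc(Oc2nc(Nc3ccc(OC)nc3)nc3c2CSCC3)c1`) gives 14600 nM. These two values lie within the scatter of each other, so compound 2 stands level with compound 1 on the present numbers.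

Compound 3 (`CCC/C=C/C(=O)Nc1cccc(Oc2nc(Nc3ccc(OC)nc3)nc3c2CSCC3)c1`) has pent-1-en-1-yl in place of vinyl on a carbonyl carbon whose other neighbour is an amide-type nitrogen: pent-1-en-1-yl in place of vinyl on a carbonyl carbon. Among the measured compounds shown here, no measured pair isolates this change. Compound 1 also carries pent-1-en-1-yl on a carbonyl carbon and gives 8190 nM, so no step beyond the scatter is expected in this assay, in either direction. The expected 1.2-fold lower number from compound 2 to compound 3 (0.09 log units; within the scatter) is small. For compound 3 the estimated value is 12000 nM, with an expected range of 5000 nM to 30000 nM.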

Compound 3, half-maximal inhibitory concentration: 10800 nM
Compound 3: the middle estimate sits 1.1-fold (0.05 log units) above what was measured, and the stated range covers the measured number.
By their numbers in this assay, from the lowest: compounds 1, 3 and 2 (each within the scatter of the next).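

In this assay, among the compounds shown here, the first matched pair for this change reads a 1.4-fold lower number from compound 2 to compound 3 (0.13 log units; within the scatter), so with 6-methoxypyridin-3-yl held fixed, pent-1-en-1-yl in place of vinyl on a carbonyl carbon leaves the two compounds level. The second place also gets its first matched reading, with pent-1-en-1-yl held fixed: 6-methoxypyridin-3-yl in place of 1-methyl-1H-pyrazol-3-yl on a nitrogen on an aromatic ring gives a 1.3-fold higher number from compound 1 to compound 3 (0.12 log units; within the scatter), which again leaves the two compounds level. Nothing on hand gives a reason for either reading.

The compounds shown leave open whether any other group on the carbonyl carbon, such as a chain ending in a dimethylamino group or a saturated pentyl chain, would give a step beyond the scatter. They also leave open whether a carboxylic acid or a morpholine on the aromatic ring carried by that nitrogen would do so.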